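The source may hold more compounds than are shown below. What is called first, only, known or untested is meant among the compounds shown, and "the series" means these compounds.

Compound 1 `OCCCCC#Cc1ccccc1C#Cc1ccc(O)cc1` and compound 2 `OCCCCC#Cc1ccccc1C#Cc1ccc(C(F)(F)F)cc1` share one core and differ at a single aromatic carbon. In a functional assay on K562 cells (Homo sapiens) for cytotoxicity (on this read-out lower numbers stand for stronger inhibition of growth and higher numbers for weaker inhibition of growth), compound 1 gives 20400 nM, and compound 2 gives 18200 nM; the two numbers lie within the scatter of one another, as the step of a 1.1-fold lower number from compound 1 to compound 2 (0.05 log units; within the scatter) shows. Compound 3 `N#Cc1ccc(C#Cc2ccccc2C#CCCCCO)cc1` carries cyano in place of trifluoromethyl on an aromatic carbon. Among the compounds with values here, the only measured step that bears on this change is a 1.1-fold lower number from compound 1 to compound 2 (0.05 log units; within the scatter), itself within the scatter, so no step beyond the scatter is expected in this assay. Compound 3 is therefore estimated at 19000 nM, with a range from 9000 nM to 40000 nM, meaning an expected step of a 1.0-fold higher number from compound 2 to compound 3 (0.02 log units; within the scatter).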

Compound 3, concentration for 50% growth inhibition: 21700 nM
Compound 3: the middle estimate sits 1.1-fold (0.06 log units) below what was measured; low and high end bracket the measured number.
By their numbers in this assay, from the lowest: compounds 2, 1 and 3 (each within the scatter of the next).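

With cyano, a third group now sits on this aromatic carbon, para to a large group, and this assay still does not separate them: the steps are a 1.2-fold higher number from compound 2 to compound 3 (0.08 log units; within the scatter) and a 1.1-fold higher number from compound 1 to compound 3 (0.03 log units; within the scatter). Trifluoromethyl, with 4 heavy atoms and no hydrogen-bond acceptor, thus gives way to cyano, with 2 heavy atoms and 1 hydrogen-bond acceptor, without a step beyond the scatter. Nothing available explains why these groups stay so close. From the compounds shown here alone, whether an amine or a carboxylic acid on this carbon would also stay within the scatter remains open.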